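Replacing the Furan on the Amine Chain

The compounds below may be only part of what the source reports. "The series", "measured", "known", "first", "only" and "open" are said of these compounds alone.

compound 1 `FC(F)(F)c1ccc(-c2ccc3c(NCCCNCc4ccco4)ccnc3c2)cc1`: 9.47
compound 2 `COc1ccccc1Oc1ccc2c(NCCCNCc3ccco3)ccnc2c1`: 9.28
compound 3 `Fc1ccc(Cc2ccc3c(NCCCNCc4ccco4)ccnc3c2)c(Cl)c1`: 9.47

Of the compounds shown here, three sharing one core have been measured in a physicochemical assay for acid dissociation. Compound 1 stands level with compound 3 at the digits shown, and the steps of a number 0.19 log units lower from compound 1 to compound 2 (within the scatter) and no change at the digits printed from compound 1 to compound 3 (within the scatter) both lie within the scatter, so the three numbers form one tight group. Compound 4 `COc1cccc(CNCCCNc2ccnc3cc(-c4ccc(C(F)(F)F)cc4)ccc23)c1O` differs from compound 1 by 2-hydroxy-3-methoxyphenyl in place of furan-2-yl on a saturated chain carbon bound to an amine nitrogen. Going by the values given here, none of the measured steps touches this part of the molecule; each alters only the group on the aromatic carbon at the other end, and none moved beyond the scatter. Nothing measured therefore bears directly on this change, and no step beyond the scatter is expected in this assay. Compound 4 is estimated at 9.4, between 8.8 and 10, a step of a number 0.07 log units lower from compound 1 to compound 4 (within the scatter).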

Compound 4, acid dissociation constant: 9.47
Beside the measured number, compound 4's estimate is 0.07 log units below it, and the stated range covers the measured number.
By their numbers in this assay, from the lowest: compounds 2, 1, 3 and 4 (each within the scatter of the next).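

Going by these compounds alone, measured by this assay, the change on a saturated chain carbon bound to an amine nitrogen shows no change at the digits printed from compound 1 to compound 4 (within the scatter), the first reading at this position, as the earlier steps altered only the group on the aromatic carbon. This exchange of furan-2-yl for 2-hydroxy-3-methoxyphenyl adds a hydrogen-bond donor and still stays within the scatter. No evidence at hand explains this result. On these data alone, whether a carboxylic acid or a second amine in place of furan-2-yl, or a longer chain, would leave the number as level remains open.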